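Amine substituent change: furan-2-yl to 1-ethoxyethyl

This account rests on a few compounds, and the source may have more. Where it says the series, first, only, none or still open, it means among the compounds named here.

Measured compounds:
compound 1 `COc1ccc(-n2cc3nc(-c4cccnc4C)n(C[C@H]4CCCN(C[C@H]5CCCO5)C4)c(=O)c3n2)cc1`, 52 nM
compound 2 `COc1cccc(-n2cc3nc(-c4cccnc4C)n(C[C@H]4CCCN(Cc5ccco5)C4)c(=O)c3n2)c1`, 2.7 nM

In an assay on HEK293 cells for displacement of a labelled ligand from growth hormone secretagogue receptor type 1 (Homo sapiens), with a stated time of 60 min (on this read-out higher numbers stand for weaker inhibition and lower numbers for stronger inhibition), compound 2 gives 2.7 nM, the lower of the two numbers, and compound 1 gives 52 nM, a higher number beyond the scatter. Within the data shown here, compounds 1 and 2 differ in more than one place, so no single step between them is known; their two values show only that compound 2 sits well below compound 1 in this assay. Compound 3 `CCO[C@@H](C)CN1CCC[C@H](Cn2c(-c3cccnc3C)nc3cn(-c4cccc(OC)c4)nc3c2=O)C1` differs from compound 2 in one place: 1-ethoxyethyl in place of furan-2-yl on a saturated chain carbon bound to an amine nitrogen in a ring. Among the measured compounds shown here, no step between measured compounds covers this change. Compound 1, which carries a saturated ring on the same amine nitrogen, shows 52 nM, while compound 2 with its furan-2-yl shows 2.7 nM, which hints at some loss when the aromatic ring is absent, though compounds 1 and 2 also differ elsewhere. The expected outcome for compound 3 is a moderate weakening, a 3.0-fold higher number from compound 2 to compound 3 (0.47 log units; beyond the scatter), rather than a return to the level of compound 1. The estimated value for compound 3 is 8 nM, with a range from 2.5 nM to 30 nM.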

Compound 3, half-maximal inhibitory concentration: 5 nM
Beside the measured number, compound 3's estimate is 1.6-fold (0.20 log units) above it; the range from low to high includes it.
By their numbers in this assay, from the lowest: compounds 2 and 3 (each within the scatter of the next); then compound 1.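

In this assay, the exchange of furan-2-yl for 1-ethoxyethyl on a saturated chain carbon bound to an amine nitrogen in a ring gives a 1.9-fold higher number from compound 2 to compound 3 (0.27 log units; within the scatter). For this pair, then, the five-membered aromatic ring can give way to an open chain with no ring and the same heavy-atom count, with no difference beyond the usual scatter; compounds 1 and 2 differ in more than one place, so they could not isolate this position. No measurement in hand accounts for the two groups reading alike.

The compounds shown leave open whether the oxygen of 1-ethoxyethyl matters here, since a plain butyl chain, which would separate the chain from its ether oxygen, does not appear among them, and the opposite configuration at its defined stereocentre does not appear either. They also leave open how far this position tolerates other kinds of group, such as a phenyl ring, a primary amine or a carboxylic acid, and whether the equivalence of furan-2-yl and 1-ethoxyethyl holds on cores carrying other substituents.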